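Adding a Second Fluorine Where Plasma Binding Is Already Complete

The source may hold more compounds than are shown below. What is called first, only, known or untested is meant among the compounds shown, and "the series" means these compounds.

Compound 1 `COc1ccc(F)cc1C1CCN(c2ccn3c(CC4CC4)nnc3c2Cl)CC1`: in an ADME assay on a cell-free system (plasma, Homo sapiens) for protein binding (on this read-out lower numbers stand for a smaller free fraction and higher numbers for a larger free fraction), compound 1 gives < 0.01, a limit of the assay.
Compound 2 `COc1cccc(F)c1C1CCN(c2ccn3c(CC4CC4)nnc3c2Cl)CC1`: in this assay compound 2 gives < 0.01, again a limit.
Compound 3 `COc1c(F)ccc(F)c1C1CCN(c2ccn3c(CC4CC4)nnc3c2Cl)CC1`: in this assay compound 3 gives < 0.01, also a limit.

Compound 1 therefore stands at the lower limit of this assay, not at a measured number, and the same holds for the two other measured compounds, as stated in the limit of < 0.01 in this assay, at which 3 of the 3 values shown sit. For that reason the step that the two limits leave unreadable from compound 1 to compound 2, the step that the two limits leave unreadable from compound 1 to compound 3 and the step that the two limits leave unreadable from compound 2 to compound 3 cannot be read in size or direction; all that can be said is that moving or adding a fluoro group on the phenyl ring kept each compound at the limit.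

Compound 4 `COc1ccc(F)c(F)c1C1CCN(c2ccn3c(CC4CC4)nnc3c2Cl)CC1` differs from compound 1 by fluoro in place of hydrogen on an aromatic carbon. The closest measured step, a step that the two limits leave unreadable from compound 2 to compound 3, also adds a fluoro group on an aromatic carbon and stayed at the limit, so no change beyond the scatter is expected. The step that the limit leaves unreadable from compound 1 to compound 4 is expected to be essentially flat. Compound 4 is expected to give 0.005 in this assay, between 0.002 and 0.012, most likely reported only as a limit.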

Compound 4, unbound fraction: < 0.01
Compound 4: a limit, no number; the forecaster's own chance of this, stated with the estimate: 85%; the middle value lies beyond the limit too.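

Compound 4 sits at the same limit as compound 1, compound 2 and compound 3, so none of its steps to those compounds can be read in size or direction: the limit of < 0.01 in this assay, at which 4 of the 4 values shown sit.

In this assay, on these data alone, the actual free fraction of all four compounds stays open, and with it whether the placement of fluoro on the phenyl ring makes any difference.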